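Benzylation of the sulfanyl group: notes on compound 4

The source may report more compounds than this note shows. Statements on the series, on what has been measured and on what is new or still open speak of the compounds shown alone.

The series shares one core and differs only in the group on the carbon between the two ring nitrogens; that carbon carries methylsulfanyl in compound 1 `CSc1nc2c(N)ncnc2n1[C@@H]1O[C@@H]2COP(=O)(O)O[C@H]2[C@H]1O`, azido in compound 2 `[N-]=[N+]=Nc1nc2c(N)ncnc2n1[C@@H]1O[C@@H]2COP(=O)(O)O[C@H]2[C@H]1O`, sulfanyl in compound 3 `Nc1ncnc2c1nc(S)n2[C@@H]1O[C@@H]2COP(=O)(O)O[C@H]2[C@H]1O` and benzylsulfanyl in compound 4 `Nc1ncnc2c1nc(SCc1ccccc1)n2[C@@H]1O[C@@H]2COP(=O)(O)O[C@H]2[C@H]1O`. In a functional assay on the whole organism for activation, with Mus musculus as the target, with stated times of 14 days and 2 h, at a dose of 30 mg/kg by the intravenous route (a lower number here means a weaker effect, a higher number a stronger effect of the compound at the dose given), compound 1 gives 804% and compound 2 gives 633%. Among the measured compounds shown here, the one step with two measured ends, a number 171 percentage points lower from compound 1 to compound 2 (beyond the scatter), shows that exchanging the sulfur group for azido costs activity. In this assay compound 3 gives no result reported, so it stands nowhere on the scale yet; the step to compound 4 therefore starts from an unknown point.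

The change itself is benzyl in place of hydrogen on a sulfur. For the measured compounds named here, no measured step touches the substituent on the sulfur: the step from compound 1 to compound 2 exchanges the whole group and does not tell how a benzyl on the sulfur compares with a hydrogen there. The closest measured point is compound 1, which also carries a carbon on that sulfur, so the expectation leans on its value rather than on any step, and no direction relative to compound 3 can be stated. Compound 4 is expected to give about 650% in this assay, with a range of 300% to 1000%.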

Compound 4, a percentage reported as activity, at one dose (the size of the read-out at that dose, not a potency): 195%
The estimate for compound 4 lay 455 percentage points above the measured number; measured number outside the range, below it.
By their numbers in this assay, from the lowest: compound 4; then compound 2; then compound 1.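

In this assay the substituent on the sulfur proves to matter: phenyl on the saturated chain carbon bound to the sulfur gives a number 609 percentage points lower from compound 1 to compound 4 (beyond the scatter), so a sulfur group on that aromatic carbon does not carry the activity by itself. Benzylsulfanyl in place of azido gives a number 438 percentage points lower from compound 2 to compound 4 (beyond the scatter), so the earlier order, with the sulfur group above azido, holds for methylsulfanyl and turns round for benzylsulfanyl, and among the three compounds with numbers compound 4 stands lowest. No measurement at hand accounts for this fall.

Compound 3 has no result in this assay, so the step from hydrogen to benzyl on the sulfur, the change itself, cannot be read. Open too, as far as these compounds go, is whether the fall goes with the phenyl ring or with any chain longer than methyl on the sulfur, a question that an ethyl or propyl chain there, or a benzyl carrying an amine or a carboxylic acid on its ring, would help to settle.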